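A few compounds are considered here, and "the series" means these few. Any claim that something is new, unique, unknown or untested is made for them only; others in the source may bear on it.

Measured so far in an ADME assay on Hepa-1c1c7 cells (Mus musculus) for cytotoxicity; on this read-out lower numbers stand for stronger inhibition and higher numbers for weaker inhibition:
- compound 1 `C=CC(O)C#CC#C[C@@H](O)[C@H](C)O`: 177000 nM
- compound 2 `CCCCCC(O)C#CC#C[C@@H](O)[C@H](C)O`: > 500000 nM (a limit, not a number)
- compound 3 `CCC/C=C/C(O)C#CC#C[C@@H](O)[C@H](C)O`: 422000 nM

Of the two actual numbers, compound 3 holds the higher, and compound 1 is the only other one available for comparison. The next structure is compound 4 `CC(C)=CC(O)C#CC#C[C@@H](O)[C@H](C)O`. The change is 2-methylprop-1-en-1-yl in place of pent-1-en-1-yl on a saturated chain carbon bound to an oxygen on a saturated carbon and a triple-bonded carbon. In words, it places 2-methylprop-1-en-1-yl in place of pent-1-en-1-yl on a saturated chain carbon bound to an oxygen on a saturated carbon and a triple-bonded carbon.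

All three measured steps concern this same place. Leaving vinyl gave a 2.4-fold higher number from compound 1 to compound 3 (0.38 log units; beyond the scatter), and also an at least 2.8-fold higher number from compound 1 to compound 2 (0.45 log units; beyond the scatter). The exchange between the two longer groups gave an at least 1.1-fold lower number from compound 2 to compound 3 (0.07 log units; that floor lies within the scatter). Among the compounds with values here, only the steps away from the vinyl of compound 1 therefore reach beyond the scatter, and both were modest at most as far as the numbers show. Compound 4 does not carry vinyl, so it is expected to stay nearer compound 3 than compound 1, perhaps drifting slightly towards the latter.

The expected change in this assay is a 1.4-fold lower number from compound 3 to compound 4 (0.13 log units; within the scatter), with no shift beyond the scatter anticipated. For compound 4 the estimated value is 310000 nM, with an expected range of 170000 nM to 500000 nM.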

Compound 4, half-maximal inhibitory concentration: 406000 nM
Estimate against measurement, compound 4: 1.3-fold (0.12 log units) below; the range from low to high includes it.
By their numbers in this assay, from the lowest: compound 1; then compounds 4 and 3 (each within the scatter of the next). At a limit, above all of these: compound 2.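

In this assay, within the data shown here, the exchange of pent-1-en-1-yl for 2-methylprop-1-en-1-yl on this saturated chain carbon gives a 1.0-fold lower number from compound 3 to compound 4 (0.02 log units; within the scatter), so these two alkenyl groups, which differ in carbon count and in shape, are not told apart here, a pairing the earlier compounds did not offer. Among these compounds, a second group that leaves vinyl gives a 2.3-fold higher number from compound 1 to compound 4 (0.36 log units; beyond the scatter), a modest step of about the same size as the one to compound 3, so compound 1 now stands apart from two different alkenyl groups rather than one. The comparison with pentyl reads only as an at least 1.2-fold lower number from compound 2 to compound 4 (0.09 log units; that floor lies within the scatter), and compound 2 is held at a limit of the assay, not a number: the limit of > 500000 nM in this assay, at which 1 of the 4 values shown sits.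

Still open, on these data alone, is whether the size of the group or something else about it separates vinyl from the larger groups, since a short saturated group such as ethyl at this place would be needed to tell, and a precise number for pentyl would be needed to compare saturated with unsaturated chains. Also open, as far as these compounds go, is how an amine, a carboxylic acid or a phenyl group on this carbon would read in this assay.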